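Acetyl for Hydrogen on an Amine: Expected Growth Inhibition

The source may report more compounds than this note shows. Statements on the series, on what has been measured and on what is new or still open speak of the compounds shown alone.

Of the compounds shown here, three sharing a benzylthio group have been measured in a functional assay on HT-29 cells (Homo sapiens) for antiproliferative activity, read by MTT assay, with a stated time of 72 h; a lower number here means a stronger inhibitor of growth, a higher number a weaker inhibitor of growth. Compound 1, `CC(=O)Nc1cc(OCC(C)C)nc(SCc2ccccc2)n1`, gives 35700 nM in this assay. Compound 2, `CCCSc1nc(N)cc(OCc2ccccc2)n1`, gives 88200 nM in this assay. Compound 3, `CC(C)Cn1c(SCc2ccccc2)nc(N)cc1=O`, returns no number in this assay, only a limit, recorded as > 100000 nM. Among the three results shown, compound 3 is the one that sits at the limit of > 100000 nM in this assay, at which 1 of the 3 values shown sits, so its standing can be given only as that limit and not as a value of its own.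

Compound 4, `CC(=O)Nc1cc(=O)n(CC(C)C)c(SCc2ccccc2)n1`, differs from compound 3 in one place: acetyl in place of hydrogen on a nitrogen on an aromatic ring. Among the compounds with values here, no pair of measured compounds differs by this change alone, so there is no measured step to lean on. Compounds 1 and 2 differ from one another in several places at once, and their values show only that both fall inside the measurable range of this assay.

With compound 3 known only as a limit, the step from compound 3 to compound 4 is estimated as an at least 1.2-fold lower number from compound 3 to compound 4 (0.09 log units; that floor lies within the scatter), which may amount to no change beyond the scatter. Compound 4 is therefore expected to give about 80000 nM in this assay, with a range from 30000 nM to 200000 nM.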

Compound 4, concentration for 50% growth inhibition: 68400 nM
For compound 4 the middle estimate is 1.2-fold (0.07 log units) above the measured one, within the range that was stated.
By their numbers in this assay, from the lowest: compounds 1, 4 and 2 (each within the scatter of the next, the first and the last beyond it). At a limit, above all of these: compound 3.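

In this assay, within the data shown here, the change from amino to acetamido, with acetyl in place of hydrogen on a nitrogen on an aromatic ring, now gives the first step that can be read between two compounds differing in one place, and it can be read only as a floor: an at least 1.4-fold lower number from compound 3 to compound 4 (0.16 log units; that floor lies within the scatter). With the acetyl group in place, compound 4 gives 68400 nM in this assay, a value of its own, where the earlier comparison had no partner for compound 3. As far as these compounds go, because compound 3 is recorded only as a limit, the true size of the step stays unknown and it may amount to no change beyond the scatter: the limit of > 100000 nM in this assay, at which 1 of the 4 values shown sits.

The compounds shown leave open whether a longer acyl chain such as propanoyl, or a methyl group, on the same nitrogen would give a different number in this assay. They also leave open whether acetyl in place of hydrogen would give a step of similar size on the core of compound 1, since this change can be read on a single pair only.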